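Acetyl in Place of Trifluoromethyl on the Shared Core

The source may hold more compounds than are shown below. What is called first, only, known or untested is meant among the compounds shown, and "the series" means these compounds.

Within the data shown here, compound 2 `O/N=C(/Nc1cccc(C(F)(F)F)c1)c1ccc2occc2c1` is the one compound of this set with a number: in an assay on isolated protein for inhibition of Indoleamine 2,3-dioxygenase 1 (Homo sapiens), read by spectrophotometry (on this read-out higher numbers stand for weaker inhibition and lower numbers for stronger inhibition), compound 2 gives 1200 nM. Compound 1 `O/N=C(/Nc1ccccc1)c1ccc2occc2c1`, the parent with hydrogen at that position, reaches only a limit in this assay, > 30000 nM; this is the limit of > 30000 nM in this assay, at which 1 of the 2 values shown sits. Among the measured compounds shown here, the single measured step is therefore an at least 25-fold lower number from compound 1 to compound 2 (1.39 log units; beyond the scatter), achieved by trifluoromethyl in place of hydrogen on an aromatic carbon.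

Compound 3 `CC(=O)c1cccc(N/C(=N/O)c2ccc3occc3c2)c1` differs from compound 2 by acetyl in place of trifluoromethyl on an aromatic carbon. For the measured compounds named here, no measured step compares acetyl with trifluoromethyl, so the only bearing comes from the step from compound 1 to compound 2, which shows that a group at this position, rather than hydrogen, matters greatly. Compound 3 keeps a group there, so a step near the scatter is expected, a 2.1-fold higher number from compound 2 to compound 3 (0.32 log units; beyond the scatter). In this assay compound 3 is estimated at 2500 nM, within 700 nM to 10000 nM.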

Compound 3, half-maximal inhibitory concentration: > 30000 nM
Compound 3 gave a limit, no number; the forecaster's own chance of this, stated with the estimate: 10%; at least 12-fold (1.07 log units) between middle value and limit.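

Acetyl in place of trifluoromethyl on the aromatic carbon brings an at least 25-fold higher number from compound 2 to compound 3 (1.39 log units; beyond the scatter), so in this assay the mere presence of a group at this place does not carry the gain seen with trifluoromethyl; which group stands there decides the result. Compound 3 gives a limit and not a number, and so does compound 1: the limit of > 30000 nM in this assay, at which 2 of the 3 values shown sit. The step from compound 1 to compound 3 therefore cannot be read, and acetyl cannot be ranked against hydrogen.

Among the compounds shown, trifluoromethyl is the only group at this place that gives a number, so a single pair of groups defines the change. On these data alone, whether chlorine, a nitrile or a methyl group there would read like trifluoromethyl or like acetyl remains open.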